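A few compounds are considered here, and "the series" means these few. Any claim that something is new, unique, unknown or untested is made for them only; others in the source may bear on it.

Measured compounds and their values:

Compound 1, `O=C1C=C(NCc2ccccc2)C(=O)c2c1nc1n2[C@H]2OC[C@@H](O)[C@H]2OC1`: in a functional assay on HeLa cells (Homo sapiens) for inhibition, read by sulforhodamine B assay (on this read-out higher numbers stand for weaker inhibition and lower numbers for stronger inhibition), compound 1 gives > 8000 nM, which is a limit of the assay and not a number.
Compound 2, `CCOc1ccccc1NC1=CC(=O)c2c(nc3n2[C@H]2OC[C@@H](O)[C@H]2OC3)C1=O`: compound 2 gives 8300 nM.
Compound 3, `CCCc1ccc(NC2=CC(=O)c3nc4n(c3C2=O)[C@H]2OC[C@@H](O)[C@H]2OC4)cc1`: compound 3 gives 4990 nM.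

Compound 2 stands highest of the two numbers shown, and its nearest neighbour, compound 3, gives a number that differs from it only within the usual scatter, so the two cannot be ranked against each other. Within the data shown here, the one measured step, an at least 1.6-fold lower number from compound 1 to compound 3 (0.20 log units; that floor lies within the scatter), starts from the limit of > 8000 nM in this assay, at which 1 of the 3 values shown sits, and its floor lies within the scatter, so it tells little about the size of any change on the amine nitrogen.

Compound 4, `O=C1C(Nc2cccc(F)c2)=CC(=O)c2c1nc1n2[C@H]2OC[C@@H](O)[C@H]2OC1`, differs from compound 2 as follows: 3-fluorophenyl in place of 2-ethoxyphenyl on an amine nitrogen. Among the measured compounds shown here, no measured pair exchanges one aromatic group for another on that nitrogen, so the step from compound 1 to compound 3 bears on it only loosely, and it was itself small. Compound 4 is therefore expected to give a number close to that of compound 2, with an expected change of a 1.3-fold lower number from compound 2 to compound 4 (0.11 log units; within the scatter) in this assay, not beyond the scatter. The estimate for compound 4 is 6500 nM, between 2500 nM and 16000 nM.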

Compound 4, half-maximal inhibitory concentration: > 8000 nM
Compound 4 ended at the assay's limit (the forecaster's own chance of this, stated with the estimate: 25%); middle value at least 1.2-fold (0.09 log units) from the limit.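

In this assay compound 4 gives > 8000 nM as a limit of the assay and not a number. The step from compound 2 to compound 4 therefore cannot be read, because it ends at that limit: the limit of > 8000 nM in this assay, at which 2 of the 4 values shown sit. The compounds shown leave open how far 3-fluorophenyl in place of 2-ethoxyphenyl on the amine nitrogen changes inhibition.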